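This account rests on a few compounds, and the source may have more. Where it says the series, first, only, none or still open, it means among the compounds named here.

Of the compounds shown here, three have numbers so far in a functional assay on B16-F10 cells (Mus musculus) for antiproliferative activity, read by colorimetric assay and MTT assay, with a stated time of 48 h; a higher number here means a weaker inhibitor, a lower number a stronger inhibitor. There, compound 1 `O=C(NS(=O)(=O)c1ccccc1)c1cccnc1` gives 14500 nM, compound 2 `Cc1ccc(S(=O)(=O)NC(=O)c2cccnc2)cc1` gives 18500 nM and compound 3 `Cc1ccc(S(=O)(=O)NC(=O)c2ccncc2)cc1` gives 16200 nM. Compound 1 therefore cannot be set apart from the other two, since all three values lie within the usual scatter of repeated measurements.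

Compound 4 `O=C(NS(=O)(=O)c1ccccc1)c1ccccn1` has the same atoms as compound 1, joined differently: pyridin-2-yl in place of pyridin-3-yl on a carbonyl carbon. In words, this is pyridin-2-yl in place of pyridin-3-yl on a carbonyl carbon.

Among the measured compounds shown here, the closest precedent is a 1.1-fold lower number from compound 2 to compound 3 (0.06 log units; within the scatter), which swaps pyridin-3-yl for pyridin-4-yl on a carbonyl carbon. The other measured change, a 1.3-fold higher number from compound 1 to compound 2 (0.11 log units; within the scatter), places methyl in place of hydrogen on an aromatic carbon and so bears on this question less directly. Pyridin-2-yl itself has not been measured, which keeps the range wide. No step beyond the scatter is expected in this assay, and the estimated step is a 1.0-fold higher number from compound 1 to compound 4 (0.01 log units; within the scatter). The estimate for compound 4 is 15000 nM, with an expected range from 8000 nM to 30000 nM.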

Compound 4, half-maximal inhibitory concentration: 14200 nM
Compound 4: middle estimate off by 1.1-fold (0.02 log units), on the high side, within the range that was stated.
By their numbers in this assay, from the lowest: compounds 4, 1, 3 and 2 (each within the scatter of the next).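

In this assay, pyridin-2-yl in place of pyridin-3-yl on a carbonyl carbon gives a 1.0-fold lower number from compound 1 to compound 4 (0.01 log units; within the scatter) and so leaves this position without a step beyond the scatter. Alongside a 1.1-fold lower number from compound 2 to compound 3 (0.06 log units; within the scatter) as a separate comparison, pyridin-2-yl, pyridin-3-yl and pyridin-4-yl have now all been seen on this carbonyl carbon, although the pyridin-4-yl step was read in compounds carrying the methyl group and the pyridin-2-yl step in compounds without it. No available evidence bears on this result.

The compounds shown leave open whether a different kind of group on this carbonyl carbon, such as an amine or a carboxylic acid, would give a step beyond the scatter. They also leave open how pyridin-2-yl reads when the methyl group of compound 2 is present.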